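Swapping dimethoxyphenyl for dimethylphenyl on the amide

The source may hold more compounds than are shown below. What is called first, only, known or untested is meant among the compounds shown, and "the series" means these compounds.

Measured compounds:
compound 1 `O=C(CN1CCN(c2nnc(Cc3ccncc3)c3ccccc23)CC1)Nc1cccc(F)c1` gives 6130 nM in a functional assay on HT-29 cells (Homo sapiens) for cytotoxicity, read by MTT assay, with a stated time of 72 h; on this read-out lower numbers stand for stronger inhibition and higher numbers for weaker inhibition
compound 2 `O=C(CN1CCN(c2nnc(Cc3ccncc3)c3ccccc23)CC1)Nc1ccc(Br)cc1` gives 1990 nM
compound 3 `COc1ccc(NC(=O)CN2CCN(c3nnc(Cc4ccccc4)c4ccccc34)CC2)cc1OC` gives 145000 nM

Compound 3 stands at the weak end of the three numbers, well beyond the scatter from both compound 1 and compound 2. Compound 4 `Cc1ccc(NC(=O)CN2CCN(c3nnc(Cc4ccccc4)c4ccccc34)CC2)c(C)c1` is not yet measured. It differs from compound 3 in one place: 2,4-dimethylphenyl in place of 3,4-dimethoxyphenyl on an amide-type nitrogen. Among the compounds with values here, the only measured step between neighbours, a 3.1-fold lower number from compound 1 to compound 2 (0.49 log units; beyond the scatter), also changes the ring on the amide nitrogen, though on a core carrying a different arm, and it produced a modest shift. Within the data shown here, no measured step trades methoxy groups for methyl groups, so the data offer no direct guide for this exact change; the nearest hint is that changing the aryl ring on the amide nitrogen moved the number only modestly. Compound 4 is therefore expected to stay near compound 3 with a modest step, a 2.4-fold lower number from compound 3 to compound 4 (0.38 log units; beyond the scatter), toward a lower number. The estimate for compound 4 in this assay is 60000 nM, within a range from 10000 nM to 300000 nM.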

Compound 4, half-maximal inhibitory concentration: "not active" (no number reported)
Nothing numeric was reported for compound 4; there is nothing to compare the estimate with.
By their numbers in this assay, from the lowest: compound 2; then compound 1; then compound 3.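

In this assay, within the data shown here, compound 4 is reported only as not active, without a number, so no step from compound 3 to compound 4 can be read. Going by these compounds, how far 2,4-dimethylphenyl in place of 3,4-dimethoxyphenyl moves the number stays open, and no supporting data bear on this result.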